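One Added Methyl on a Core That Shows No Cytotoxicity

A few compounds are considered here, and "the series" means these few. Any claim that something is new, unique, unknown or untested is made for them only; others in the source may bear on it.

Of the compounds shown here, three have been tested in a functional assay on NUGC cells (Homo sapiens) for cytotoxicity, read by MTT assay, with a stated time of 24 h; on this read-out lower numbers stand for stronger inhibition and higher numbers for weaker inhibition. Compound 1 `O=C1c2ccccc2C(=O)N1c1ccc(S)cc1` gives only a limit there, > 200000 nM. Compound 2 `Cc1ccc2c(c1)C(=O)N(c1ccc([N+](=O)[O-])cn1)C2=O` likewise reaches only a limit, > 200000 nM. Compound 3 `Nc1ccc(CN2C(=O)c3ccccc3C2=O)cc1` also shows only a limit in this assay, > 200000 nM. Compound 3 thus stands where every tested compound stands, at the limit of > 200000 nM in this assay, at which 3 of the 3 values shown sit, and nothing separates it from the other two. Compound 4 `Cc1cccc2c1C(=O)N(Cc1ccc(N)cc1)C2=O` differs from compound 3 by methyl in place of hydrogen on an aromatic carbon. Among the compounds with values here, with no measured step of this kind to draw on, no shift beyond the usual scatter is expected in this assay, in either direction. Compound 4 is therefore expected to give about 300000 nM, within 100000 nM to 1000000 nM, an expected step that the limit leaves unreadable from compound 3 to compound 4, and most likely another limit rather than a number.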

Compound 4, half-maximal inhibitory concentration: > 200000 nM
Compound 4 gave a limit, no number (the forecaster's own chance of this, stated with the estimate: 85%); the middle value is on the limit's open side.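

No step can be read from compound 3 to compound 4, because both give only a limit in this assay: the limit of > 200000 nM in this assay, at which 4 of the 4 values shown sit.

The compounds shown leave open whether methyl in place of hydrogen on an aromatic carbon has any effect on cytotoxicity.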